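The compounds below may be only part of what the source reports. "The series", "measured", "known", "first", "only" and "open" are said of these compounds alone.

Compound 2 `CN(C(=O)NC(=O)c1cccc(C(F)(F)F)c1)c1nc(C(F)(F)F)c(C(=O)N/N=C/c2ccccc2C(F)(F)F)s1` is one of two compounds here for which a functional assay on BCG823 cells (Homo sapiens) for inhibition, read by MTT assay, with a stated time of 72 h (on this read-out higher numbers stand for weaker inhibition and lower numbers for stronger inhibition), returned a number rather than a limit. In this assay compound 2 gives 7.29 ug/mL. Its closest neighbour is compound 1 `CN(C(=O)NC(=O)c1cccc(C(F)(F)F)c1)c1nc(C(F)(F)F)c(C(=O)N/N=C/c2ccc(C(F)(F)F)cc2)s1`, which in this assay gives 4.22 ug/mL; the step of a 1.7-fold higher number from compound 1 to compound 2 (0.24 log units; within the scatter) lies within the scatter, so the two compounds cannot be told apart. Compound 3 `CN(C(=O)NC(=O)c1ccc(C(F)(F)F)cc1)c1nc(C(F)(F)F)c(C(=O)N/N=C/c2ccc(C(F)(F)F)cc2)s1` differs from compound 1 only on the carbonyl carbon, and in this assay compound 3 gives only a limit, > 100 ug/mL, which is the limit of > 100 ug/mL in this assay, at which 1 of the 3 values shown sits.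

Compound 4 `CN(C(=O)NC(=O)c1ccccc1F)c1nc(C(F)(F)F)c(C(=O)N/N=C/c2ccccc2C(F)(F)F)s1` is reached from compound 2 by 2-fluorophenyl in place of 3-(trifluoromethyl)phenyl on a carbonyl carbon. The step at this same carbonyl carbon, an at least 23-fold higher number from compound 1 to compound 3 (1.37 log units; beyond the scatter), was the only large one seen, which marks this position as one where a change in the aryl group can cost much inhibition. The step at the other aryl ring, a 1.7-fold higher number from compound 1 to compound 2 (0.24 log units; within the scatter), was small and does not bear on the new change.

Compound 4 is therefore expected to give a weaker number, with a 3.4-fold higher number from compound 2 to compound 4 (0.54 log units; beyond the scatter). The estimate for compound 4 is 25 ug/mL, within 6 ug/mL to 100 ug/mL.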

Compound 4, half-maximal inhibitory concentration: 4.67 ug/mL
Estimate against measurement, compound 4: 5.4-fold (0.73 log units) above; the measured number lies below the stated range.
By their numbers in this assay, from the lowest: compounds 1, 4 and 2 (each within the scatter of the next). At a limit, above all of these: compound 3.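

At the carbonyl carbon, 2-fluorophenyl can take the place of 3-(trifluoromethyl)phenyl with no measurable loss in this assay, the step being a 1.6-fold lower number from compound 2 to compound 4 (0.19 log units; within the scatter). A change of aryl group at this position therefore need not cost inhibition, so the large loss seen earlier belongs to one particular change and not to every change made here. Compound 3 remains the only compound shown that gives a limit and not a number: the limit of > 100 ug/mL in this assay, at which 1 of the 4 values shown sits.

The groups shown on this carbonyl carbon are all phenyl rings carrying fluorine or trifluoromethyl, which leaves open how an unsubstituted phenyl, a phenyl ring bearing an amine or a carboxylic acid, or a simple alkyl chain would behave. On these data alone, the 2-fluorophenyl group has also been read only with 2-(trifluoromethyl)phenyl on the other aryl ring, so its behaviour with 4-(trifluoromethyl)phenyl there remains open.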